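A few compounds are considered here, and "the series" means these few. Any claim that something is new, unique, unknown or untested is made for them only; others in the source may bear on it.

Measured so far in an ADME assay on HCT-15 cells (Homo sapiens) for cytotoxicity; on this read-out lower numbers stand for an effect already at smaller amounts and higher numbers for an effect only at larger amounts of compound:
compound 1 `O=C(C1=NC(c2c[nH]c3cc(Br)ccc23)CN1)c1c[nH]c2ccccc12` — 9.8 ug/mL
compound 2 `O=C(C1=NC(c2c[nH]c3ccccc23)CN1)c1c[nH]c2cc(Br)ccc12` — > 30 ug/mL (a limit)

In this assay compound 1 gives 9.8 ug/mL. Compound 2 gives only > 30 ug/mL in this assay, which is a limit of the assay and not a number. Compound 2 therefore sits at the limit of > 30 ug/mL in this assay, at which 1 of the 2 values shown sits.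

Compound 3 `O=C(C1=NC(c2c[nH]c3cc(Br)ccc23)CN1)c1c[nH]c2cc(Br)ccc12` has not yet been measured in this assay. Compound 3 differs from compound 2 by bromo in place of hydrogen on an aromatic carbon. For the measured compounds named here, no step between two measured compounds that differ in a single place is available, and with compound 2 known only as a limit, the step to compound 3 cannot be counted from the data; compound 1 shows that a bromo-bearing member of the series can register a numerical value in this assay. The step expected from compound 2 to compound 3 is an at least 2.0-fold lower number from compound 2 to compound 3 (0.30 log units; that floor lies within the scatter), toward an effect at smaller amounts, though this expectation is loosely held. For compound 3 the estimated value in this assay is 15 ug/mL, with a range from 5 ug/mL to 40 ug/mL.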

Compound 3, concentration for half-maximal effect: 4.88 ug/mL
The estimate for compound 3 lay 3.1-fold (0.49 log units) above the measured number, and the stated range ends above it.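

In this assay, bromo in place of hydrogen on an aromatic carbon of compound 2 gives an at least 6.1-fold lower number from compound 2 to compound 3 (0.78 log units; beyond the scatter) and brings the series to a numerical reading at this position. The same kind of change on compound 1 gives a 2.0-fold lower number from compound 1 to compound 3 (0.30 log units; within the scatter) and stays within the usual scatter, so compound 3 is not separated from compound 1. Among these compounds, the added bromo therefore gives a step beyond the scatter only when it enters on compound 2, and compound 3 carries both bromo groups.

On these data alone, whether chloro, a methoxy group or an amine on the same aromatic carbon would read like bromo stays open. Compound 2 is held only as a limit and not a number, so the full size of its step also stays open: the limit of > 30 ug/mL in this assay, at which 1 of the 3 values shown sits.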